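This account rests on a few compounds, and the source may have more. Where it says the series, first, only, none or still open, it means among the compounds named here.

In an ADME assay (on this read-out higher numbers stand for a longer-lived compound and lower numbers for a shorter-lived compound), compound 1 `COc1ccc(C[S+]([O-])c2ncccc2C(=O)Nc2ccncc2)c(OCCF)c1` gives < 0.02 h as a limit of the assay. Compound 2 `COc1ccc(C[S+]([O-])c2ncccc2C(=O)Nc2ccncc2)c(OCCO)c1` stands at < 0.02 h as a limit too. Compound 3 `COc1ccc(C[S+]([O-])c2ncccc2C(=O)Nc2ccncc2)cc1` differs from compound 2 by hydrogen in place of 2-hydroxyethoxy on an aromatic carbon with hydrogen in place of 2-hydroxyethoxy on an aromatic carbon. For the measured compounds named here, the only measured step that the two limits leave unreadable from compound 1 to compound 2 changes that same chain but has no readable size, so it shows no direction. Going by the values given here, with the limit of < 0.02 h in this assay, at which 2 of the 2 values shown sit, as the only guide, no step beyond the scatter is expected in this assay and the estimated change a step that the limit leaves unreadable from compound 2 to compound 3 is expected to stay within it. For compound 3 the estimate is 0.015 h with an expected range from 0.008 h to 0.05 h and the assay may again report only a limit.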

Compound 3, half-life: 2.14 h
The estimate for compound 3 lay 140-fold (2.15 log units) below the measured number; the whole stated range lies below it.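

In this assay, hydrogen in place of 2-hydroxyethoxy gives an at least 100-fold higher number from compound 2 to compound 3 (2.02 log units; beyond the scatter), and hydrogen in place of 2-fluoroethoxy gives an at least 100-fold higher number from compound 1 to compound 3 (2.02 log units; beyond the scatter). What sits on this aromatic carbon, ortho to a large group, therefore matters greatly, whereas the step between the two chains, from compound 1 to compound 2, cannot be read. Both new steps give only a minimum size, because each starts from a limit: the limit of < 0.02 h in this assay, at which 2 of the 3 values shown sit.

The compounds shown leave open whether a small group here, such as methoxy or a single fluorine atom, would keep the half-life of compound 3. They also leave open whether a chain ending in an amine would behave like the two chains shown.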